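Methylating the Sulfonamide Nitrogen: An Expected Loss

The source may hold more compounds than are shown below. What is called first, only, known or untested is meant among the compounds shown, and "the series" means these compounds.

Compound 1 `O=S(=O)(O)c1ccc(F)c2ncc(I)cc12` gives 2300 nM in an assay for inhibition of methylcytosine dioxygenase TET2 (Homo sapiens), read by mass spectrometry, with stated times of 30 min and 1 h; on this read-out higher numbers stand for weaker inhibition and lower numbers for stronger inhibition.
Compound 2 `CC(C)OS(=O)(=O)c1ccc(F)c2ncc(I)cc12` gives only a limit in this assay, > 200000 nM.
Compound 3 `NS(=O)(=O)c1ccc(F)c2ncc(I)cc12` gives 86600 nM in this assay.

Among the two numbers shown, compound 3 stands highest; its nearest neighbour is compound 1, the step being a 38-fold higher number from compound 1 to compound 3 (1.58 log units; beyond the scatter). Compound 4 `CNS(=O)(=O)c1ccc(F)c2ncc(I)cc12` differs from compound 3 by methyl in place of hydrogen on a sulfonamide nitrogen. For the measured compounds named here, two measured steps bear on this: a 38-fold higher number from compound 1 to compound 3 (1.58 log units; beyond the scatter), where amino replaced hydroxy on the sulfonyl sulfur, and an at least 86-fold higher number from compound 1 to compound 2 (1.93 log units; beyond the scatter), where an isopropyl group replaced the hydrogen on the oxygen. Both were large losses. A methyl replacing the hydrogen on the sulfonamide nitrogen is expected to weaken inhibition further, likely a 2.1-fold higher number from compound 3 to compound 4 (0.32 log units; beyond the scatter). Compound 4 is therefore estimated at 180000 nM, within 40000 nM to 600000 nM, with a fair chance of reaching the assay limit (the limit of > 200000 nM in this assay, at which 1 of the 3 values shown sits).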

Compound 4, half-maximal inhibitory concentration: > 200000 nM
Compound 4: no number, only a limit (the forecaster's own chance of this, stated with the estimate: 45%); middle value at least 1.1-fold (0.04 log units) away from the limit.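

Earlier compounds changed only what sits on the sulfonyl sulfur; this result shows that the sulfonamide nitrogen is also sensitive, since one added methyl gives an at least 2.3-fold higher number from compound 3 to compound 4 (0.36 log units; beyond the scatter). Measured from the hydroxy compound, the total change is an at least 86-fold higher number from compound 1 to compound 4 (1.93 log units; beyond the scatter). Compound 4 gives only a limit, so these steps show the smallest possible loss, and its step from compound 2 cannot be read: the limit of > 200000 nM in this assay, at which 2 of the 4 values shown sit.

The compounds shown leave open how much further strength the methyl costs. They also leave open whether a carboxylic acid in place of the sulfonyl group would recover the strength of compound 1.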